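A few compounds are considered here, and "the series" means these few. Any claim that something is new, unique, unknown or untested is made for them only; others in the source may bear on it.

In an ADME assay on microsomes from liver (Rattus norvegicus) for metabolic stability, with a stated time of 10 min (on this read-out higher numbers stand for a more stable compound and lower numbers for a less stable compound), three compounds of one series have been measured:

compound 1, `O=C(NS(=O)(=O)c1ccc(F)cc1)c1ccc(Nc2nc(NC3(c4ccc(Cl)cc4)CC3)nc(OCC(F)(F)F)n2)cc1`, gives 99%
compound 2, `CC(C)C(=O)NCCS(=O)(=O)NC(=O)c1ccc(Nc2nc(NC3(c4ccc(Cl)cc4)CC3)nc(OCC(F)(F)F)n2)cc1`, gives 84%
compound 3, `O=C(NS(=O)(=O)C1CC1)c1ccc(Nc2nc(NC3(c4ccc(Cl)cc4)CC3)nc(OCC(F)(F)F)n2)cc1`, gives 85%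

Compound 3 stands below compound 1 in this assay by a number 14 percentage points lower from compound 1 to compound 3 (beyond the scatter), and beside compound 2, since a number 1 percentage points higher from compound 2 to compound 3 (within the scatter). The two compounds that do not carry the 4-fluorophenyl group on the sulfonyl sulfur thus sit close together, with compound 1 apart from both.

Compound 4, `NCCS(=O)(=O)NC(=O)c1ccc(Nc2nc(NC3(c4ccc(Cl)cc4)CC3)nc(OCC(F)(F)F)n2)cc1`, is not yet measured. It differs from compound 3 in one place: 2-aminoethyl in place of cyclopropyl on a sulfonyl sulfur. The step that bears on it most directly is the one between the two non-aromatic sulfonyl substituents, where a number 1 percentage points higher from compound 2 to compound 3 (within the scatter); the step of a number 15 percentage points lower from compound 1 to compound 2 (beyond the scatter) shows that an acylated aminoethyl chain on the sulfonyl sulfur also lands near the value of compound 3. Among the measured compounds shown here, no measured step involves a free 2-aminoethyl group, so the expectation rests on those two comparisons. Compound 4 is therefore expected to give a step of about a number 5 percentage points lower from compound 3 to compound 4 (within the scatter) in this assay, that is, none beyond the scatter. For compound 4 the estimate in this assay is 80%, with a range from 65% to 95%.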

Compound 4, percent of the compound remaining: 100%
For compound 4 the middle estimate is 20 percentage points below the measured one, outside the stated range (above it).
By their numbers in this assay, from the lowest: compounds 2 and 3 (each within the scatter of the next); then compounds 1 and 4 (each within the scatter of the next).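

The result shows that a non-aromatic group on this sulfonyl sulfur need not land with compound 2 and compound 3: in this assay the change to 2-aminoethyl gives a number 15 percentage points higher from compound 3 to compound 4 (beyond the scatter), and putting hydrogen in place of isopropylcarbonyl on the amine nitrogen of that chain gives a number 16 percentage points higher from compound 2 to compound 4 (beyond the scatter). The 4-fluorophenyl group is also not alone in reaching the higher level, since 2-aminoethyl in its place gives a number 1 percentage points higher from compound 1 to compound 4 (within the scatter). Nothing available explains why these groups differ in this way.

The compounds shown leave open whether a longer chain ending in an amine, or a methylated amine on the ethyl chain, would stay at the level of the 2-aminoethyl group. They also leave open what a carboxylic acid at the end of that chain would give.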